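The source may report more compounds than this note shows. Statements on the series, on what has been measured and on what is new or still open speak of the compounds shown alone.

Three retinoid-type carboxylic acids were compared in an assay on isolated protein with retinoic acid receptor beta (Homo sapiens) as the target; a lower number here means a smaller maximal response, a higher number a larger maximal response. Compound 1, `CC1(C)CCC(C)(C)c2cc(C(=O)c3ccc4cc(C(=O)O)ccc4c3)c(O)cc21`, carries a hydroxy group on the ring bearing the tetramethyl-substituted bicyclic core, and in this assay compound 1 reaches 76%. Compound 2, `COc1cc2c(cc1C(=O)c1ccc3cc(C(=O)O)ccc3c1)C(C)(C)CCC2(C)C`, is its methyl ether, and in this assay compound 2 reaches 61%. Going by the values given here, the single change between them, (hydrogen in place of methyl on an oxygen on an aromatic ring), gives a step of a number 15 percentage points higher from compound 2 to compound 1 (beyond the scatter).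

Compound 3, `COc1c(C(=O)c2ccc3c(c2)C(C)(C)CCC3(C)C)ccc2cc(C(=O)O)ccc12`, is built from the same atoms as compound 2 but joined differently: the methoxy group now sits on the naphthalene portion rather than on the bicyclic portion. The difference between the two cores is not broken down here. In this assay compound 3 gives 0%, the lowest of the three numbers and well beyond the scatter below both compound 2 and compound 1.

Compound 4, `CC1(C)CCC(C)(C)c2cc(C(=O)c3ccc4cc(C(=O)O)ccc4c3O)ccc21`, relates to compound 3 as compound 1 relates to compound 2, through the same change, (hydrogen in place of methyl on an oxygen on an aromatic ring). Since compound 3 shows no response at all, the modest gain seen from compound 2 to compound 1 is expected to lift compound 4 only a little, because the same change earlier gave a number 15 percentage points higher from compound 2 to compound 1 (beyond the scatter) on a core that already responded. Compound 4 is therefore estimated to show a step of a number 10 percentage points higher from compound 3 to compound 4 (within the scatter). Compound 4 is expected to reach about 10%, most likely between 0% and 35%.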

Compound 4, largest response reached (reported as maximum), in percent of the reference or control that the assay uses: 0%
Estimate against measurement, compound 4: 10 percentage points above; the range from low to high includes it.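

In this assay, replacing methoxy with hydroxy on the second core gives no change at the digits printed from compound 3 to compound 4 (within the scatter). The change therefore does not carry over from one core to the other with the same size, and the gain seen on the first core is not repeated on the second: the same change on two cores in this assay, a number 15 percentage points higher (beyond the scatter) from compound 2 to compound 1 and no change at the digits printed (within the scatter) from compound 3 to compound 4, 15 percentage points apart, beyond the scatter of two such steps

This shows that the result of this single change depends on the core that carries it, at least for these two pairs, but it does not show what in the cores causes the difference, and two pairs give no general rule for the series. Nor does it show that hydroxy has no effect on the second core under all conditions, since compound 3 and compound 4 were compared here only in this one assay, where compound 4 gives 0%.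

The compounds shown leave open how an amine or a fluorine in place of the hydroxy group, or an ethoxy group in place of the methoxy group, would read in this assay on either core. They also leave open whether an amide in place of the carboxylic acid would alter the difference between the two cores.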